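Adding trifluoromethyl to an isopropoxycarbonyl group

A few compounds are considered here, and "the series" means these few. Any claim that something is new, unique, unknown or untested is made for them only; others in the source may bear on it.

Within the data shown here, in a functional assay on HepG2 cells (Homo sapiens) for inhibition, read by scintillation counting, with a stated time of 2 h (on this read-out higher numbers stand for weaker inhibition and lower numbers for stronger inhibition), compound 2 `CCNC(=O)Nc1sc2ccccc2c1C(=O)N1CCN(C2CCN(C(=O)OC(C)C)CC2)CC1` gives 208 nM, the only number available, while compound 1 `CCNC(=O)Nc1sc2ccccc2c1C(=O)N1CCN(C2CCN(C(C)=O)CC2)CC1` stands as "not determined" (no result reported). Compound 2 therefore has no measured neighbour to be ranked against. Compound 3 `CCNC(=O)Nc1sc2ccccc2c1C(=O)N1CCN(C2CCN(C(=O)OC(C)(C)C(F)(F)F)CC2)CC1` turns isopropoxycarbonyl into (1-methyl-1-(trifluoromethyl)ethoxy)carbonyl: trifluoromethyl in place of hydrogen on a saturated chain carbon bound to an oxygen next to a carbonyl group and two saturated chain carbons. Among the measured compounds shown here, no measured step shows what such a change does, so only a modest move towards stronger inhibition in this assay is expected, possibly no larger than the scatter. The expected size is a 1.7-fold lower number from compound 2 to compound 3 (0.24 log units; within the scatter). For compound 3 the estimated value is 120 nM, within an expected range of 35 nM to 400 nM.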

Compound 3, half-maximal inhibitory concentration: 81 nM
For compound 3 the middle estimate is 1.5-fold (0.17 log units) above the measured one; the measured number falls inside the stated range.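

In this assay, trifluoromethyl in place of hydrogen on this saturated chain carbon gives a 2.6-fold lower number from compound 2 to compound 3 (0.41 log units; beyond the scatter). Among these compounds, this is the first measured step, and it shows that the change at this position goes with stronger inhibition, not weaker. Nothing available explains the gain.

As far as these compounds go, it remains open whether the tert-butoxycarbonyl group, with methyl in place of the trifluoromethyl, would lower the number as far. Also open, from the compounds shown here alone, is what a single fluorine or a cyclopropyl group on that carbon would do.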